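The source may report more compounds than this note shows. Statements on the series, on what has been measured and on what is new or still open speak of the compounds shown alone.

In an assay on isolated protein for inhibition of Alpha glucosidase (Homo sapiens), read by spectrophotometry, with stated times of 15 min and 30 min (on this read-out higher numbers stand for weaker inhibition and lower numbers for stronger inhibition), three compounds built on two related cores have been measured. Compound 1 `O=C1NC(=O)/C(=C/c2ccccc2OCN2C(=O)c3ccccc3C2=O)S1` gives in this assay only a limit, > 100000 nM. Compound 1 sits at the limit of > 100000 nM in this assay, at which 1 of the 3 values shown sits. Compound 2 `O=C1NC(=O)/C(=C/c2cc([N+](=O)[O-])ccc2OCN2C(=O)c3ccccc3C2=O)S1` gives in this assay 50500 nM. The change between them is nitro in place of hydrogen on an aromatic carbon, and it made an at least 1.9-fold lower number from compound 1 to compound 2 (0.29 log units; that floor lies within the scatter). Compound 3 `O=C1NC(=S)S/C1=C\c1ccc(OCN2C(=O)c3ccccc3C2=O)cc1` carries a different core; the difference between the two cores is not broken down here. In this assay compound 3 gives 7910 nM, the lowest of the two numbers obtained.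

Compound 4 `O=C1NC(=S)S/C1=C\c1ccc(OCN2C(=O)c3ccccc3C2=O)c([N+](=O)[O-])c1` has not yet been measured. It differs from compound 3 by nitro in place of hydrogen on an aromatic carbon. Among the compounds with values here, this is the same kind of change as the one from compound 1 to compound 2, though the place is not the same word for word: in compound 2 the nitro sits meta to a group of 8 heavy atoms and para to a large group, whereas in compound 4 it sits ortho to a large group and meta to a group of 8 heavy atoms. The expectation rests on an at least 1.9-fold lower number from compound 1 to compound 2 (0.29 log units; that floor lies within the scatter). The expected step is a 1.6-fold lower number from compound 3 to compound 4 (0.20 log units; within the scatter). Compound 4 is therefore estimated at 5000 nM, with a range from 1500 nM to 16000 nM.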

Compound 4, half-maximal inhibitory concentration: 6590 nM
Beside the measured number, compound 4's estimate is 1.3-fold (0.12 log units) below it, and the stated range covers the measured number.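

In this assay, nitro in place of hydrogen on an aromatic carbon of the second core gives a 1.2-fold lower number from compound 3 to compound 4 (0.08 log units; within the scatter) and so makes no difference that stands out from the usual scatter of repeated measurements. Set beside the earlier case, the two steps compare as follows: the same change on two cores in this assay, an at least 1.9-fold lower number (0.29 log units; that floor lies within the scatter) from compound 1 to compound 2 and a 1.2-fold lower number (0.08 log units; within the scatter) from compound 3 to compound 4; the limit leaves it open whether they differ. Compound 1 gives > 100000 nM as a limit of the assay, so the earlier step has no exact size, and these two steps show neither that the change carries over from one core to the other nor that it does not.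

The compounds shown leave open whether a different group on this ring, such as an amine or a carboxylic acid, would shift the number on either core. They also leave open what nitro would do on each core if it held the place it has on the other, since the two nitro compounds carry it in different places.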